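From Thiophen-2-yl to Thiophen-3-yl: A Small Expected Step

The compounds below may be only part of what the source reports. "The series", "measured", "known", "first", "only" and "open" are said of these compounds alone.

In a functional assay on HL-60 cells (Homo sapiens) for cytotoxicity, read by XTT assay, with a stated time of 3 days (a lower number here means a stronger inhibitor, a higher number a weaker inhibitor), compound 1 `OC[C@H]1O[C@@H](n2cc(Cl)c3c(-c4ccccc4)ncnc32)[C@H](O)[C@@H]1O` gives 1200 nM, while compound 2 `OC[C@H]1O[C@@H](n2cc(Cl)c3c(-c4cccs4)ncnc32)[C@H](O)[C@@H]1O` gives 5500 nM, the higher of the two numbers and so the weaker inhibitor. Within the data shown here, the only measured step, a 4.6-fold higher number from compound 1 to compound 2 (0.66 log units; beyond the scatter), replaced phenyl with thiophen-2-yl. Compound 3 `OC[C@H]1O[C@@H](n2cc(Cl)c3c(-c4ccsc4)ncnc32)[C@H](O)[C@@H]1O` has the same atoms joined differently: thiophen-3-yl in place of thiophen-2-yl on an aromatic carbon. No measurement covers this exact swap, and the group remains a thiophene, so a smaller change than that measured step is expected. The expected shift is a 1.8-fold lower number from compound 2 to compound 3 (0.26 log units; within the scatter), toward a lower number. For compound 3 the estimated value is 3000 nM, within a range of 800 nM to 9000 nM.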

Compound 3, half-maximal inhibitory concentration: 1600 nM
Estimate against measurement, compound 3: 1.9-fold (0.27 log units) above; the measured number falls inside the stated range.
By their numbers in this assay, from the lowest: compounds 1 and 3 (each within the scatter of the next); then compound 2.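

Where the sulfur sits relative to the attachment point matters at this position: with the same atoms, joined differently, this assay shows a 3.4-fold lower number from compound 2 to compound 3 (0.54 log units; beyond the scatter) and so separates the two thiophenes. Replacing phenyl with thiophen-3-yl gives a 1.3-fold higher number from compound 1 to compound 3 (0.12 log units; within the scatter) and the two cannot be told apart, so the weaker result with thiophen-2-yl does not extend to thiophenes in general. Nothing available explains this difference. On these data alone, whether a furan ring or an amine at this position would sit nearer compound 1 or compound 2 remains open.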